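The compounds below may be only part of what the source reports. "The series", "measured", "known", "first", "only" and "open" are said of these compounds alone.

In a functional assay on the whole organism with Mus musculus as the target, in the maximal electroshock model (on this read-out lower numbers stand for an effect already at smaller amounts and higher numbers for an effect only at larger amounts of compound), compound 1 `CC1CCSC1=O` gives 91 mg/kg, the lowest of the two numbers at hand; compound 2 `CCC1CCSC1=O` gives 232 mg/kg. Compound 3 `CC(C)C1CCSC1=O` reaches only a limit, > 500 mg/kg. Compound 4 `CC1(C)CCSC1=O` is not yet measured and differs from compound 1 by methyl in place of hydrogen on a saturated ring carbon. Two measured steps add carbon to the core of compound 1: a 2.5-fold higher number from compound 1 to compound 2 (0.41 log units; beyond the scatter), and an at least 5.4-fold higher number from compound 1 to compound 3 (0.73 log units; beyond the scatter), compound 3 being the one at the limit of > 500 mg/kg in this assay, at which 1 of the 3 values shown sits. Both point upward, so a second methyl on the ring carbon is expected to raise the number as well, by about a 2.2-fold higher number from compound 1 to compound 4 (0.34 log units; beyond the scatter). Compound 4 is therefore estimated at 200 mg/kg in this assay, with a range from 100 mg/kg to 450 mg/kg.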

Compound 4, dose for half-maximal effect: 369 mg/kg
Compound 4: middle estimate off by 1.8-fold (0.27 log units), on the low side, and the stated range covers the measured number.
By their numbers in this assay, from the lowest: compound 1; then compounds 2 and 4 (each within the scatter of the next). At a limit, above all of these: compound 3.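

In this assay, a second methyl on the saturated ring carbon, two ring bonds from the ring sulfur, gives a 4.1-fold higher number from compound 1 to compound 4 (0.61 log units; beyond the scatter). Until now, the added carbon had appeared only in a chain on this ring carbon; here it sits on the ring carbon itself, and the number still rises. Among the compounds shown, no added carbon at this position goes against that direction.

All the groups here are made of carbon and hydrogen only. From the compounds shown here alone, how an amine or a hydroxyl group on this ring carbon would read remains open.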